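The source may report more compounds than this note shows. Statements on the series, on what has been measured and on what is new or still open speak of the compounds shown alone.

Measured compounds in a physicochemical assay for lipophilicity, read by HPLC, in phosphate buffer, measured as chromatographic lipophilicity, at pH 7.4; on this read-out lower numbers stand for lower lipophilicity and higher numbers for higher lipophilicity:

- compound 1, `Cc1cc(C)cc(NC(=O)COc2cc(C)nc3ccc(OC(F)(F)F)cc23)c1`: 6.79
- compound 2, `Cc1cc(C)cc(NC(=O)COc2cc(C)nc3ccc(OCc4ccccc4)cc23)c1`: 7.03
- compound 3, `COc1ccc2nc(C)cc(OCC(=O)Nc3cc(C)ccc3C)c2c1`: 5.05

Among these three, compound 3 gives the lowest number, and each of the other two sits beyond the scatter above it: compound 1 is the nearer of the two and compound 2 the further. Among the measured compounds shown here, the only step between two measured compounds that differ in one place is a number 0.24 log units higher from compound 1 to compound 2 (within the scatter), and it concerns a group on an oxygen on an aromatic ring, not the part of the molecule that changes here.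

Compound 4, `COc1ccc2nc(C)cc(OCC(=O)Nc3ccncn3)c2c1`, has not yet been measured. It differs from compound 3 in one place: pyrimidin-4-yl in place of 2,5-dimethylphenyl on an amide-type nitrogen. For the measured compounds named here, no measured step covers a change on the amide-type nitrogen, so the expectation has to rest on the change itself: a six-membered aromatic ring of carbon only with two methyl groups gives way to a smaller ring with two hetero atoms and two hydrogen-bond acceptors. In this assay that kind of exchange is expected to lower the number, and by more than the scatter. The estimated step is a number 2.05 log units lower from compound 3 to compound 4 (beyond the scatter). For compound 4 the expected value is 3, with a range from 2.2 to 3.8.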

Compound 4, distribution coefficient: 2.53
Estimate against measurement, compound 4: 0.47 log units above, within the range that was stated.
By their numbers in this assay, from the lowest: compound 4; then compound 3; then compounds 1 and 2 (each within the scatter of the next).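

In this assay, the group on the amide-type nitrogen proves to be a place where one exchange moves the number a long way: with the rest of the molecule unchanged, pyrimidin-4-yl in place of 2,5-dimethylphenyl gives a number 2.52 log units lower from compound 3 to compound 4 (beyond the scatter). Among the compounds shown here, the only step available before this one concerned a group on an oxygen on an aromatic ring and stayed within the scatter, so the earlier compounds gave no measure of what a change on the amide-type nitrogen can do. Nothing measured separately here speaks to what lies behind the size of this step.

The exchange alters several things at once, as the ring gains two nitrogen atoms and loses its two methyl groups, so this one step cannot say how much of the drop belongs to each of those changes. A plain phenyl ring or a pyridinyl ring on the same nitrogen would help to divide it, while the same pyrimidin-4-yl exchange with benzyl or trifluoromethyl in place of the methyl on the core's oxygen would test whether a step of this size carries over.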